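This account rests on a few compounds, and the source may have more. Where it says the series, first, only, none or still open, it means among the compounds named here.

The three measured compounds share one core and differ only in the group attached to one aromatic carbon. Compound 1 `O=S(=O)(Cc1nc(-c2ccc(Cl)nc2)c2sccc2n1)c1cccc(Cl)c1` carries a 6-chloropyridin-3-yl there, and in an ADME assay on cells (Homo sapiens) for cytotoxicity, read by resazurin assay, with a stated time of 5 days (a lower number here means that less compound is tolerated, a higher number that more compound is tolerated), compound 1 gives 70000 nM. Compound 2 `O=S(=O)(Cc1nc(-c2ccoc2)c2sccc2n1)c1cccc(Cl)c1` carries a furan-3-yl instead. In this assay compound 2 gives > 50000 nM, which is a limit of the assay rather than a number. Compound 3 `COc1ccc(-c2nc(CS(=O)(=O)c3cccc(Cl)c3)nc3ccsc23)cn1` carries a 6-methoxypyridin-3-yl. In this assay compound 3 gives > 10000 nM, again a limit and not a number. Because of the limit of > 10000 nM in this assay, at which 1 of the 3 values shown sits, and the limit of > 50000 nM in this assay, at which 1 of the 3 values shown sits, the sizes of the steps a step that the limit leaves unreadable from compound 1 to compound 2, a step that the limit leaves unreadable from compound 1 to compound 3 and a step that the two limits leave unreadable from compound 2 to compound 3 cannot be read, so the three values cannot be set in order. Compound 4 `COc1ccc(Nc2nc(CS(=O)(=O)c3cccc(Cl)c3)nc3ccsc23)cc1` has not yet been measured. The change from compound 3 is (4-methoxyphenyl)amino in place of 6-methoxypyridin-3-yl on an aromatic carbon. With no readable step to lean on, no movement beyond the usual scatter is expected, and compound 4 is estimated at 40000 nM, between 12000 nM and 100000 nM. That estimate means an expected step that the limit leaves unreadable from compound 3 to compound 4.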

Compound 4, half-maximal cytotoxic concentration: 60000 nM
The estimate for compound 4 lay 1.5-fold (0.18 log units) below the measured number; measured number inside the range.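

Among the compounds shown, compound 4 is the only one that joins its group to the shared core through an amino nitrogen, and its entering group is the one that brings a hydrogen-bond donor to this position. In this assay, among the compounds shown here, the one readable comparison is a 1.2-fold lower number from compound 1 to compound 4 (0.07 log units; within the scatter), so (4-methoxyphenyl)amino and 6-chloropyridin-3-yl cannot be told apart here. The steps from compound 2 and compound 3 to compound 4 cannot be read, since each of those two compounds stands at a limit of the assay and not at a number: the limit of > 10000 nM in this assay, at which 1 of the 4 values shown sits, and (the limit of > 50000 nM in this assay, at which 1 of the 4 values shown sits).

Where compound 2 and compound 3 truly lie remains open. So does whether a different kind of group at this position, such as a simple alkyl amine or a carboxylic acid, would leave the number in the same range.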